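Swapping methoxy for (4-nitrobenzyl)oxy on a shared core

The source may report more compounds than this note shows. Statements on the series, on what has been measured and on what is new or still open speak of the compounds shown alone.

Measured so far in a functional assay on HepG2 cells (Homo sapiens) for antiproliferative activity, read by MTT assay, with a stated time of 24 h; on this read-out higher numbers stand for weaker inhibition and lower numbers for stronger inhibition:
- Compound 1 `COc1ccc2c(=O)c(-c3cc(OC)c(OC)cc3OC)coc2c1`: 2040 nM
- Compound 3 `COc1cc(OC)c(-c2coc3cc(OCc4ccccc4F)ccc3c2=O)cc1OC`: 1280 nM
- Compound 2 `COc1cccc(C(=O)Oc2ccc3c(=O)c(-c4cc(OC)c(OC)cc4OC)coc3c2)c1`: a limit only, > 10000 nM

Compound 1 holds the highest of the two real numbers; compound 3 sits a 1.6-fold lower number from compound 1 to compound 3 (0.20 log units; within the scatter) away, within the scatter. Compound 2 stops at the limit of > 10000 nM in this assay, at which 1 of the 3 values shown sits. Compound 4 `COc1cc(OC)c(-c2coc3cc(OCc4ccc([N+](=O)[O-])cc4)ccc3c2=O)cc1OC` is not yet measured and differs from compound 1 in one spot: 4-nitrophenyl in place of hydrogen on a saturated chain carbon bound to an oxygen on an aromatic ring. Going by the values given here, the closest precedent is the step that placed 2-fluorophenyl on that same carbon, a 1.6-fold lower number from compound 1 to compound 3 (0.20 log units; within the scatter), while an at least 4.9-fold higher number from compound 1 to compound 2 (0.69 log units; beyond the scatter) concerns a (3-methoxyphenyl)carbonyl on the oxygen and is less comparable. Compound 4 is therefore expected to give 1500 nM, between 600 nM and 4000 nM, a step of a 1.4-fold lower number from compound 1 to compound 4 (0.13 log units; within the scatter) that is expected to stay within the scatter.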

Compound 4, half-maximal inhibitory concentration: 2500 nM
Compound 4: middle estimate off by 1.7-fold (0.22 log units), on the low side, and the stated range covers the measured number.
By their numbers in this assay, from the lowest: compounds 3, 1 and 4 (each within the scatter of the next). At a limit, above all of these: compound 2.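

On this saturated chain carbon, 4-nitrophenyl gives a result in this assay that cannot be told apart from hydrogen or from 2-fluorophenyl: a 1.2-fold higher number from compound 1 to compound 4 (0.09 log units; within the scatter) and a 2.0-fold higher number from compound 3 to compound 4 (0.29 log units; within the scatter). So two differently substituted rings on this carbon both leave the number within the scatter of compound 1, whereas the (3-methoxyphenyl)carbonyl on the oxygen stays apart, with an at least 4.0-fold lower number from compound 2 to compound 4 (0.60 log units; beyond the scatter). Compound 2 stands at a limit, not a number: the limit of > 10000 nM in this assay, at which 1 of the 4 values shown sits.

As far as these compounds go, whether an amine or a carboxylic acid on this ring would move the number remains open. So does the effect of a longer chain on the oxygen.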